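Chain-extended secondary amide on the shared naphthol core

The compounds below may be only part of what the source reports. "The series", "measured", "known", "first", "only" and "open" are said of these compounds alone.

Working notes on the series. For the measured compounds named here, compound 1 `O=C(c1c(O)ccc2cc(-c3cccc(O)c3)ccc12)N1CCOCC1` carries a (morpholin-4-yl)carbonyl group on the shared core; in an in vitro assay on Sf9 cells for inhibition of 17-beta-hydroxysteroid dehydrogenase type 1 (Homo sapiens), tested at 1 uM (a lower number here means a weaker effect, a higher number a stronger effect of the compound at the concentration tested), compound 1 gives 62%, the higher of the two numbers measured so far. Compound 2 `CNC(=O)c1cc2cc(-c3cccc(O)c3)ccc2cc1O` bears a methylcarbamoyl group directly on the core, and in this assay compound 2 gives 18%, a number well below that of compound 1 and beyond the scatter. Going by the values given here, the two compounds differ in more than one place, so no single step joins them.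

Compound 3 `CNC(=O)CCc1c(O)ccc2cc(-c3cccc(O)c3)ccc12` is the unmeasured member. It differs from compound 1 in one place: 2-(methylcarbamoyl)ethyl in place of (morpholin-4-yl)carbonyl on an aromatic carbon. Among the compounds with values here, no step between measured compounds shows the effect of such a change, so the size of the step can only be estimated. Within the data shown here, the 2-(methylcarbamoyl)ethyl group has no measured counterpart. A downward step is expected, a number 22 percentage points lower from compound 1 to compound 3 (beyond the scatter), smaller than the gap seen between the two measured compounds. Compound 3 is expected to give 40% in this assay, with a range from 15% to 65%.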

Compound 3, a percentage reported as inhibition, at one concentration (the size of the read-out at that concentration, not a potency): 80%
Estimate against measurement, compound 3: 40 percentage points below; measured number above the stated range.
By their numbers in this assay, from the lowest: compound 2; then compound 1; then compound 3.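

On an aromatic carbon ortho to a hydroxy group, 2-(methylcarbamoyl)ethyl in place of (morpholin-4-yl)carbonyl gives a number 18 percentage points higher from compound 1 to compound 3 (beyond the scatter) in this assay, the first step read at this position in the series. The six-membered non-aromatic ring of compound 1 is therefore not required for the read-out here, and an open chain with fewer heavy atoms and a hydrogen-bond donor is accepted at this place, on the evidence of this single pair. No measurement available for these compounds explains the direction or size of this step.

Loss of the ring, the longer link to the carbonyl and gain of the amide hydrogen all change together in this pair, so their shares of the step remain unseparated; a 2-(dimethylcarbamoyl)ethyl group, a 3-(methylcarbamoyl)propyl chain or a 2-carboxyethyl group at the same carbon would pull these changes apart. For the compounds shown here, compound 2 remains joined by no single step to compound 1 or compound 3, so how its methylcarbamoyl group relates to this position stays open.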